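Returning the fluoro group with an added methyl

A few compounds are considered here, and "the series" means these few. Any claim that something is new, unique, unknown or untested is made for them only; others in the source may bear on it.

Compound 3 `CN1C(=O)C(c2cccc(C(F)(F)F)c2)N(C)c2nc(Nc3ccc(S(N)(=O)=O)cc3)ncc21` stands highest of the three numbers in an assay on Sf9 cells for inhibition of serine/threonine-protein kinase 4 (Homo sapiens), read by luminescence and ADP-Glo, with a stated time of 1 h, in the presence of a further agent that is not named here (a lower number here means a stronger inhibitor, a higher number a weaker inhibitor), with compound 3 giving 2710 nM. Compound 1 `CCCC1C(=O)N(C)c2cnc(Nc3ccc(S(N)(=O)=O)cc3)nc2N1C` gives 206 nM and compound 2 `CN1C(=O)C(c2cccc(F)c2)N(C)c2nc(Nc3ccc(S(N)(=O)=O)cc3)ncc21` gives 134 nM. The step of a 20-fold higher number from compound 2 to compound 3 (1.31 log units; beyond the scatter) and the step of a 13-fold higher number from compound 1 to compound 3 (1.12 log units; beyond the scatter) both place compound 3 far beyond the scatter, while a 1.5-fold lower number from compound 1 to compound 2 (0.19 log units; within the scatter) is within it. Compound 4 `Cc1c(F)cccc1C1C(=O)N(C)c2cnc(Nc3ccc(S(N)(=O)=O)cc3)nc2N1C` differs from compound 3 in one place: 3-fluoro-2-methylphenyl in place of 3-(trifluoromethyl)phenyl on a saturated ring carbon. This change reverses the exchange that separated compound 2 from compound 3, and adds a methyl; the steps bearing on it are those large steps into compound 3. A large lower number is therefore expected, an 11-fold lower number from compound 3 to compound 4 (1.04 log units; beyond the scatter), landing near compound 2 and compound 1. Compound 4 is estimated at 250 nM, within 80 nM to 800 nM.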

Compound 4, half-maximal inhibitory concentration: 419 nM
Beside the measured number, compound 4's estimate is 1.7-fold (0.22 log units) below it; the range from low to high includes it.
By their numbers in this assay, from the lowest: compounds 2 and 1 (each within the scatter of the next); then compound 4; then compound 3.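

In this assay, 3-fluoro-2-methylphenyl on the saturated ring carbon wins back much of what 3-(trifluoromethyl)phenyl gave up, with a 6.5-fold lower number from compound 3 to compound 4 (0.81 log units; beyond the scatter), yet the added methyl on the aromatic carbon carries its own cost, at a 3.1-fold higher number from compound 2 to compound 4 (0.50 log units; beyond the scatter), and the group also falls on the weaker side of propyl, with a 2.0-fold higher number from compound 1 to compound 4 (0.31 log units; beyond the scatter). Nothing measured here accounts for these steps. The compounds shown leave open whether a chloro or methoxy group in place of that methyl would cost as much, and whether a chain longer than propyl would hold up on this carbon.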